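One Chlorophenyl in Place of Another on Compound 1

The source may hold more compounds than are shown below. What is called first, only, known or untested is meant among the compounds shown, and "the series" means these compounds.

Compound 1 `CCC1(CCCCN2CCN(c3ccc(C)c(Cl)c3)CC2)C(=O)Nc2ccccc21` was tested in a functional assay on the whole organism (strain Wistar) with Rattus norvegicus as the target, with a stated time of 5 min; a higher number here means that more compound is needed for the effect, a lower number that less compound is needed. In this assay compound 1 gave only a limit, > 20 mg/kg, so no exact number is known for it. That limit is the limit of > 20 mg/kg in this assay, at which 1 of the 3 values shown sits. Compound 2 `O=C1Nc2ccc(F)cc2C1CCCCN1CCN(c2ccc(F)cc2)CC1` also reached only a limit in this assay, > 10 mg/kg. That limit is the limit of > 10 mg/kg in this assay, at which 1 of the 3 values shown sits. Within the data shown here, compound 3 `CCC1(CCCCN2CCN(c3cccc(Cl)c3)CC2)C(=O)Nc2cc(F)c(Cl)cc21` is the one compound with a measured number, giving 20 mg/kg in this assay. Compound 1 therefore stands at a limit, and the three values together say only that all of these compounds need large doses.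

Compound 4 `CCC1(CCCCN2CCN(c3ccccc3Cl)CC2)C(=O)Nc2ccccc21` has not been measured. It differs from compound 1 in one place: 2-chlorophenyl in place of 3-chloro-4-methylphenyl on an amine nitrogen in a ring. Among the measured compounds shown here, no pair of measured compounds differing in a single place is available, so the size of this step cannot be read from the data. The step that the limit leaves unreadable from compound 1 to compound 4 is expected to stay within the usual scatter. Compound 4 is estimated to need 30 mg/kg in this assay, between 10 mg/kg and 100 mg/kg, with a fair chance that only a limit is reported again.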

Compound 4, minimum effective dose: > 20 mg/kg
Compound 4 was reported as a limit; the forecaster's own chance of this, stated with the estimate: 60%; the middle value does not contradict the limit.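

In this assay compound 1 and compound 4 both reached only a limit, not an exact number, so the step between them cannot be read: the limit of > 20 mg/kg in this assay, at which 2 of the 4 values shown sit.

Still open, as far as these compounds go, is whether 2-chlorophenyl in place of 3-chloro-4-methylphenyl changes the dose needed, and what exact dose either compound requires.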